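This account rests on a few compounds, and the source may have more. Where it says the series, first, only, none or still open, it means among the compounds named here.

In a functional assay on HCC827 cells (Homo sapiens) for inhibition, read by fluorescence, with a stated time of 72 h (a lower number here means a stronger inhibitor of growth, a higher number a weaker inhibitor of growth), compound 1 (`COc1ccc(Cn2cnc3c(Nc4cccc(Cl)c4)nc(N[C@H]4CC[C@H](N)CC4)nc32)cc1`) gives 18700 nM while compound 2 (`CCCCn1cnc2c(NCc3cccc(Cl)c3)nc(N[C@H]3CC[C@H](N)CC3)nc21`) gives 10600 nM and compound 3 (`CC(C)CCn1cnc2c(Nc3cccc(Cl)c3)nc(N[C@H]3CC[C@H](N)CC3)nc21`) gives 10300 nM as its value. Compound 3 thus stands within the scatter of both other compounds, and the three numbers cannot be ranked. Compound 4 (`CCCCn1cnc2c(Nc3cccc(Cl)c3)nc(N[C@H]3CC[C@H](N)CC3)nc21`) differs from compound 3 in its chain, which goes from isopentyl to butyl (hydrogen in place of methyl on a saturated chain carbon bound to two saturated chain carbons), with hydrogen in place of methyl on a saturated chain carbon bound to two saturated chain carbons. Within the data shown here, the one measured step at this chain is the exchange of 4-methoxyphenyl for isobutyl (a 1.8-fold lower number from compound 1 to compound 3 (0.26 log units; within the scatter)) and it stayed within the scatter although it is a much larger change. Compound 2 already carries a butyl chain and shows 10600 nM but also differs from compound 4 elsewhere. No step beyond the scatter is therefore expected in this assay for this smaller change. The estimate for compound 4 is 11000 nM (expected range 6000 nM to 20000 nM).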

Compound 4, concentration for 50% growth inhibition: 7200 nM
Estimate against measurement, compound 4: 1.5-fold (0.18 log units) above; low and high end bracket the measured number.
By their numbers in this assay, from the lowest: compounds 4, 3, 2 and 1 (each within the scatter of the next, the first and the last beyond it).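

In this assay, shortening isopentyl to butyl gives only a small step (a 1.4-fold lower number from compound 3 to compound 4 (0.16 log units; within the scatter)), so this methyl can go without a change beyond the scatter. With the butyl chain in place, 3-chlorophenyl in place of 3-chlorobenzyl on the nitrogen also stays within it (a 1.5-fold lower number from compound 2 to compound 4 (0.17 log units; within the scatter)). Against the 4-methoxyphenyl of compound 1, however, the butyl chain gives a modest step beyond the scatter (a 2.6-fold lower number from compound 1 to compound 4 (0.41 log units; beyond the scatter)), while the isopentyl chain stayed within it (a 1.8-fold lower number from compound 1 to compound 3 (0.26 log units; within the scatter)).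

On these data alone, whether a longer chain, or a chain ending in an amine or a carboxylic acid, in place of the butyl chain would shift the number remains open. No available evidence bears on the reason for these steps.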